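The source may hold more compounds than are shown below. What is called first, only, known or untested is meant among the compounds shown, and "the series" means these compounds.

Of the compounds shown here, two in this set have been measured in an ADME assay on A549 cells (Homo sapiens) for cytotoxicity, read by MTT assay; on this read-out higher numbers stand for lower toxicity in this test and lower numbers for higher toxicity in this test. Compound 1, with the structure `CCCCC#Cc1cn([C@@H]2O[C@H](CO)[C@@H](O)[C@H]2O)c(=O)[nH]c1=O`, carries a sugar on its core and a chain ending in a triple bond; in this assay compound 1 gives 83200 nM. Compound 2, with the structure `CCCCCCC#Cc1c[nH]c(=O)[nH]c1=O`, lacks the sugar and has a longer chain; in this assay compound 2 gives 249000 nM. Of the two numbers, that of compound 1 is the lower one, and the gap to compound 2 is beyond the usual scatter, so compound 1 is the more toxic of the pair in this test.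

Compound 3, with the structure `CCCCCCC#Cc1cn([C@@H]2O[C@H](CO)[C@@H](O)[C@H]2O)c(=O)[nH]c1=O`, is not yet measured. Compared with compound 1 the change is ethyl in place of hydrogen on a saturated chain carbon, four bonds along the chain from a triple-bonded carbon. Among the measured compounds shown here, no measured pair differs in this one place alone, so there is no directly comparable step to lean on. The step from compound 1 to compound 3 is expected to be small, a 1.2-fold lower number from compound 1 to compound 3 (0.08 log units; within the scatter), with no clear direction beyond the scatter. Compound 3 is therefore expected to give about 70000 nM in this assay, within a range of 25000 nM to 200000 nM.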

Compound 3, half-maximal cytotoxic concentration: 87200 nM
Compound 3: middle estimate off by 1.2-fold (0.10 log units), on the low side; measured number inside the range.
By their numbers in this assay, from the lowest: compounds 1 and 3 (each within the scatter of the next); then compound 2.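

In this assay, ethyl in place of hydrogen on a saturated chain carbon, four bonds along the chain from a triple-bonded carbon, gives a 1.0-fold higher number from compound 1 to compound 3 (0.02 log units; within the scatter) and so makes no difference that this test can separate from ordinary repeat variation. Among the compounds shown here, compound 3 also provides the first pair with the same chain, one form carrying the sugar and the other lacking it: compound 2 gives 249000 nM and compound 3 gives 87200 nM as the printed numbers for that single difference. No measurement available here explains either result.

Only one change in chain length is shown at this position, so a longer chain, or a chain ending in an amine or a carboxylic acid, could give a different number. On these data alone, the core without the sugar appears here with only one chain, so whether ethyl in place of hydrogen would also leave the number within the scatter on that form remains open.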